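Bromine added to a coumarin-linked aldehyde: expected cytotoxicity

This account rests on a few compounds, and the source may have more. Where it says the series, first, only, none or still open, it means among the compounds named here.

Of the compounds shown here, two have been measured in an ADME assay on HEK-293T cells (Homo sapiens) for cytotoxicity, read by MTT assay, with a stated time of 24 h; a higher number here means a weaker inhibitor, a lower number a stronger inhibitor. Compound 1 `C#CCOc1c(/C=N/Cc2ccc(S(N)(=O)=O)cc2)cccc1OC` gives 135000 nM. Compound 2 `O=Cc1ccccc1OCc1cn(CCCOc2ccc3ccc(=O)oc3c2)nn1` gives 13700 nM, the lower of the two numbers, and the gap between compound 2 and compound 1 lies beyond the usual scatter of this assay, so compound 2 is the stronger inhibitor of the pair.

Compound 3 `O=Cc1cc(Br)ccc1OCc1cn(CCCOc2ccc3ccc(=O)oc3c2)nn1` is not yet measured. It differs from compound 2 in one place: bromo in place of hydrogen on an aromatic carbon.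

Among the measured compounds shown here, no measured pair shows what a bromo for hydrogen exchange of this kind does in this assay, so the step can only be guessed. A single bromine on an aromatic carbon is a small change, and the step from compound 2 to compound 3 is expected to stay within the scatter or to lower the number slightly, as a 1.4-fold lower number from compound 2 to compound 3 (0.14 log units; within the scatter). Compound 3 is therefore estimated at 10000 nM, with a range from 4000 nM to 30000 nM.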

Compound 3, half-maximal inhibitory concentration: 6080 nM
For compound 3 the middle estimate is 1.6-fold (0.22 log units) above the measured one; measured number inside the range.
By their numbers in this assay, from the lowest: compound 3; then compound 2; then compound 1.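

In this assay, the bromo that enters meta to the formyl group and para to the large group gives a 2.3-fold lower number from compound 2 to compound 3 (0.35 log units; beyond the scatter), a modest step but one beyond the scatter. Among the compounds shown here, this is the first change in a single place that can be read, and it shows that the number responds to a substitution at this carbon of the 2-formylphenoxy part. Nothing available accounts for this shift.

On these data alone, what a chloro, a methoxy or an amine at this same carbon would do remains open, so the step cannot yet be tied to bromo in particular. Also open, as far as these compounds go, is how the number would respond if the formyl group gave way to a carboxylic acid, or if the chain to the coumarin were longer.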